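Notes on the step from compound 2 to compound 3

The compounds below may be only part of what the source reports. "The series", "measured", "known", "first", "only" and "open" are said of these compounds alone.

Measured values (a functional assay on HT-29 cells (Homo sapiens) for cytotoxicity, read by MTT assay, with a stated time of 72 h; a higher number here means a weaker inhibitor, a lower number a stronger inhibitor):
- compound 1 `CC(C)c1[nH]cnc1/C=c1\[nH]c(=O)/c(=C/c2cccc(C(=O)c3ccc(F)cc3)c2)[nH]c1=O` gives 0.8 nM
- compound 2 `COCc1ccc(/C=c2\[nH]c(=O)/c(=C/c3cccc(Oc4ccc(F)cc4)c3)[nH]c2=O)o1` gives 7 nM

Compound 2 holds the higher number of the two, and its gap to compound 1 lies beyond the scatter. Compound 3 `COCc1ccc(/C=c2\[nH]c(=O)/c(=C/c3cccc(C(=O)c4ccc(F)cc4)c3)[nH]c2=O)o1` has (4-fluorophenyl)carbonyl in place of 4-fluorophenoxy on an aromatic carbon. Among the measured compounds shown here, no measured step isolates this change. Compound 1 gives 0.8 nM while also carrying (4-fluorophenyl)carbonyl, so a modest step to a lower number in this assay is expected. The expected size is a 2.8-fold lower number from compound 2 to compound 3 (0.45 log units; beyond the scatter) on this estimate. The estimate for compound 3 is 2.5 nM (range 0.7 nM to 10 nM).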

Compound 3, half-maximal inhibitory concentration: 2.2 nM
Estimate against measurement, compound 3: 1.1-fold (0.06 log units) above; the measured number falls inside the stated range.
By their numbers in this assay, from the lowest: compound 1; then compound 3; then compound 2.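

In this assay, among the compounds shown here, (4-fluorophenyl)carbonyl in place of 4-fluorophenoxy gives a 3.2-fold lower number from compound 2 to compound 3 (0.50 log units; beyond the scatter) and is the first isolated reading of this change on the aromatic carbon, with 5-(methoxymethyl)furan-2-yl held fixed. With (4-fluorophenyl)carbonyl held fixed, 5-(methoxymethyl)furan-2-yl in place of 5-isopropyl-1H-imidazol-4-yl gives a 2.8-fold higher number from compound 1 to compound 3 (0.44 log units; beyond the scatter) and shows that this second place also moves the number by a modest step. No measured evidence bears on the cause of either step.

On these data alone, whether the carbonyl step holds with 5-isopropyl-1H-imidazol-4-yl present remains open. So does the reading of an amine or a carboxylic acid at this aromatic carbon.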